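This account rests on a few compounds, and the source may have more. Where it says the series, first, only, none or still open, it means among the compounds named here.

Of the compounds shown here, three sharing one core have been tested in an assay on Sf9 cells for inhibition of serine/threonine-protein kinase 4 (Homo sapiens), read by luminescence and ADP-Glo, with a stated time of 1 h, in the presence of a further agent that is not named here; a higher number here means a weaker inhibitor, a lower number a stronger inhibitor. Compound 1 `CN1C(=O)C(C2CC2)N(C)c2nc(Nc3ccc(S(N)(=O)=O)cc3)ncc21` carries a cyclopropyl on a saturated ring carbon and gives 136 nM. Compound 2 `CCCC1C(=O)N(C)c2cnc(Nc3ccc(S(N)(=O)=O)cc3)nc2N1C` carries a propyl at the same place and gives 206 nM; the step of a 1.5-fold higher number from compound 1 to compound 2 (0.18 log units; within the scatter) lies within the scatter. Compound 3 `CN1C(=O)C(c2cccc(C(F)(F)F)c2)N(C)c2nc(Nc3ccc(S(N)(=O)=O)cc3)ncc21` carries a 3-(trifluoromethyl)phenyl there and gives 2710 nM, the highest of the three numbers, so it is the weakest inhibitor of the set. The steps of a 20-fold higher number from compound 1 to compound 3 (1.30 log units; beyond the scatter) and a 13-fold higher number from compound 2 to compound 3 (1.12 log units; beyond the scatter) are both large and point the same way: the 3-(trifluoromethyl)phenyl on that carbon, in place of either small alkyl, went with a clearly weaker inhibitor.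

Compound 4 `Cc1ccc(F)cc1C1C(=O)N(C)c2cnc(Nc3ccc(S(N)(=O)=O)cc3)nc2N1C` has not yet been measured. Its change from compound 3 is 5-fluoro-2-methylphenyl in place of 3-(trifluoromethyl)phenyl on a saturated ring carbon. Within the data shown here, both groups are aryl groups, so this is a swap of one aryl for another, and no measured step covers such a swap. The measured steps say only that an aryl at this carbon sits well above the small alkyls. The expected step of a 1.4-fold lower number from compound 3 to compound 4 (0.13 log units; within the scatter) is therefore small, within the scatter, with no firm direction. Compound 4 is estimated at 2000 nM in this assay, with a likely range from 600 nM to 7000 nM.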

Compound 4, half-maximal inhibitory concentration: 168 nM
Estimate against measurement, compound 4: 12-fold (1.08 log units) above, outside the stated range (below it).
By their numbers in this assay, from the lowest: compounds 1, 4 and 2 (each within the scatter of the next); then compound 3.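

In this assay, the large step (a 16-fold lower number from compound 3 to compound 4 (1.21 log units; beyond the scatter)) shows that carrying an aryl group on this saturated ring carbon does not in itself go with a weak inhibitor, since exchanging one aryl group for another here changes the number by far more than the scatter. The steps (a 1.2-fold lower number from compound 2 to compound 4 (0.09 log units; within the scatter)) and (a 1.2-fold higher number from compound 1 to compound 4 (0.09 log units; within the scatter)) both lie within the scatter, so the 5-fluoro-2-methylphenyl cannot be told apart from the propyl or the cyclopropyl, and the weak result at this position now belongs to the 3-(trifluoromethyl)phenyl of compound 3 alone, not to aryl groups as a class. Nothing available explains why the two aryl groups differ so widely.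

The two aryl groups differ in more than one feature at once, so these compounds cannot say whether losing the trifluoromethyl or gaining the fluorine or the methyl goes with the stronger inhibition. They also leave open how a plain phenyl, a methylphenyl, a fluorophenyl or a chain ending in an amine on this carbon would compare.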